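Working notes: fluoro for methyl, compound 2 to compound 4

The compounds below may be only part of what the source reports. "The series", "measured", "known", "first", "only" and "open" are said of these compounds alone.

In a functional assay on HeLa cells (Homo sapiens) for cytotoxicity, read by MTT assay, with a stated time of 48 h (on this read-out lower numbers stand for stronger inhibition and higher numbers for weaker inhibition), compound 1 `CCOC(=O)c1c(-c2cc3ccccc3oc2=O)nn(-c2ccccc2)c1C(=O)OCC` gives 100000 nM, compound 3 `CCOC(=O)c1c(-c2cc3ccccc3oc2=O)nn(-c2ccc(OC)cc2)c1C(=O)OCC` gives 90000 nM, and compound 2 `COC(=O)c1c(-c2cc3ccccc3oc2=O)nn(-c2cccc(C)c2)c1C(=O)OC` gives 45000 nM. Compound 2 has the lowest number of the three; its gap to compound 3 lies within the scatter, while its gap to compound 1 lies beyond it. Going by the values given here, the only single-point step measured so far, a 1.1-fold lower number from compound 1 to compound 3 (0.05 log units; within the scatter), stays within the scatter. Compound 4 `COC(=O)c1c(-c2cc3ccccc3oc2=O)nn(-c2cccc(F)c2)c1C(=O)OC` differs from compound 2 by fluoro in place of methyl on an aromatic carbon. Among the compounds with values here, no measured step involves a fluoro for methyl exchange, and the one measured change on an aromatic carbon moved nothing beyond the scatter, so for compound 4 no shift beyond the scatter is expected in this assay, no change at the digits printed from compound 2 to compound 4 (within the scatter). Compound 4 is therefore estimated at 45000 nM, with a range from 20000 nM to 100000 nM.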

Compound 4, half-maximal inhibitory concentration: 76000 nM
Compound 4: the middle estimate sits 1.7-fold (0.23 log units) below what was measured; the measured number falls inside the stated range.
By their numbers in this assay, from the lowest: compounds 2, 4, 3 and 1 (each within the scatter of the next, the first and the last beyond it).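

In this assay, 3-fluorophenyl in place of 3-methylphenyl gives a 1.7-fold higher number from compound 2 to compound 4 (0.23 log units; within the scatter), so this read-out does not separate fluoro from methyl on this aromatic carbon, meta to a large group. This is the second measured change on an aromatic carbon to stay within the scatter. No data at hand bear on the cause of this step.

From the compounds shown here alone, whether an amine or a carboxylic acid on this carbon would move the number beyond the scatter remains open. So does whether the same exchange reads alike with the ethyl esters.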